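Shorter chain and ethyl piperazine after an isopropyl setback

The source may hold more compounds than are shown below. What is called first, only, known or untested is meant among the compounds shown, and "the series" means these compounds.

Compound 1 `CN1CCN(CCCNC(=O)n2c(=O)n(C3CC3)c3ccccc32)CC1`: 0.46
Compound 2 `CC(C)n1c(=O)n(C(=O)NCCCN2CCN(C)CC2)c2ccccc21`: < 0.3
Compound 3 `CCCn1c(=O)n(C(=O)NCCN2CCN(C)CC2)c2ccccc21`: 0.48

In a functional assay for agonist activity at 5-hydroxytryptamine receptor 4 (Cavia porcellus) (on this read-out lower numbers stand for smaller maximal responses and higher numbers for larger maximal responses), compound 1 gives 0.46 and compound 3 gives 0.48; these two values lie within the usual scatter of each other. For compound 2 this assay reports only a limit, < 0.3. Compound 2 therefore stands lowest of the three, separated from the other two by more than the scatter. For the measured compounds named here, the single measured step, a number at least 0.16 lower from compound 1 to compound 2 (beyond the scatter), describes this drop, and its true size is hidden by the limit of < 0.3 in this assay, at which 1 of the 3 values shown sits.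

Compound 4 `CCN1CCN(CCNC(=O)n2c(=O)n(C(C)C)c3ccccc32)CC1` has not yet been measured in this assay. It differs from compound 2 in this way: 4-ethylpiperazin-1-yl in place of (4-methylpiperazin-1-yl)methyl on a saturated chain carbon, two bonds along the chain from an amide-type nitrogen. Going by the values given here, no measured step follows the same change; the measured step concerns the group on the aromatic nitrogen, which compound 4 keeps as isopropyl. Compound 3 carries the same shorter chain but a propyl group, and its value shows only that such a chain is compatible with a measurable response. Compound 4 is expected to give about 0.3, with a likely range from 0.15 to 0.48. The step of a number no lower from compound 2 to compound 4 (the limit leaves the size open) is an estimate only, and since compound 2 sits at a limit the assay may again report no number.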

Compound 4, intrinsic activity: the largest response reached, as a fraction of the reference agonist's: 0.87
Compound 4: middle estimate off by 0.57, on the low side, and the stated range ends below it.
By their numbers in this assay, from the lowest: compounds 1 and 3 (each within the scatter of the next); then compound 4. At a limit, below all of these: compound 2.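

In this assay, moving from (4-methylpiperazin-1-yl)methyl to 4-ethylpiperazin-1-yl on a saturated chain carbon, two bonds along the chain from an amide-type nitrogen, gives a number at least 0.57 higher from compound 2 to compound 4 (beyond the scatter). This place therefore has a large say in the maximal response, even though the two groups have the same heavy-atom count and the isopropyl group on the aromatic nitrogen stays the same, so that isopropyl group does not by itself hold the response down, and compound 4 reaches 0.87. The true size of the step stays open because compound 2 is reported only as a limit: the limit of < 0.3 in this assay, at which 1 of the 4 values shown sits.

The compounds shown do not separate the shorter chain from the ethyl group in place of methyl on the piperazine, since the two differences arrive together in this one change, so neither can yet be credited with the gain. Going by these compounds, it also remains open whether a 4-propylpiperazin-1-yl or a morpholin-4-yl group at this place would keep so large a response.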